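The source may report more compounds than this note shows. Statements on the series, on what has been measured and on what is new or still open speak of the compounds shown alone.

Compound 1 `CC1(C)C=C(n2ccccc2=O)c2cc(C(=O)c3ccccc3)ccc2O1` gives 6.21 in a functional assay (trachea) with Rattus norvegicus as the target; a higher number here means a more potent compound, by a factor of ten per unit of this negative logarithm, a lower number a less potent compound.
Compound 2 `CC1(C)C=C(n2ccccc2=O)c2cc(C(=O)c3ccccc3F)ccc2O1` gives 6.34 in this assay.
Compound 3 `CC1(C)C=C(n2ccccc2=O)c2cc(OCC(=O)c3ccccc3)ccc2O1` gives 4.69 in this assay.

Compound 2 differs from compound 1 by fluoro in place of hydrogen on an aromatic carbon, and the step is a number 0.13 log units higher from compound 1 to compound 2 (within the scatter). Compound 3 has the lowest of the three numbers; its values with compound 1 and compound 2 lie beyond the scatter. The difference between the core of compound 3 and that of compound 1 is not broken down here. Compound 4 `CC1(C)C=C(n2ccccc2=O)c2cc(OCC(=O)c3ccc(F)cc3)ccc2O1` is not yet measured; it differs from compound 3 by fluoro in place of hydrogen on an aromatic carbon. This is the same kind of change as that from compound 1 to compound 2, though there the fluoro sits ortho to a large group and here para to a large group. Because the earlier step was a number 0.13 log units higher from compound 1 to compound 2 (within the scatter), the step is expected to be a number 0.06 log units higher from compound 3 to compound 4 (within the scatter). Compound 4 is thus estimated at 4.75, between 4.3 and 5.2.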

Compound 4, logarithm of the reciprocal of the active concentration, log(1/C): 4.77
Compound 4: the middle estimate sits 0.02 log units below what was measured; the measured number falls inside the stated range.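

In this assay, fluoro in place of hydrogen on an aromatic carbon gives a number 0.08 log units higher from compound 3 to compound 4 (within the scatter). Set beside the earlier case, the change reads alike on the two cores: the same change on two cores in this assay, a number 0.13 log units higher (within the scatter) from compound 1 to compound 2 and a number 0.08 log units higher (within the scatter) from compound 3 to compound 4, 0.05 log units apart, within the scatter of two such steps. This shows that on these two cores the change leaves the number within the scatter, but it does not show that this would hold on another core, and it cannot separate the effect of the core from that of the fluoro's place, which differs between the two pairs.

The compounds shown leave open whether chloro, methoxy or trifluoromethyl in the same place would give a step beyond the scatter. Also open, going by these compounds, is what an amine or a carboxylic acid there would do.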